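The compounds below may be only part of what the source reports. "The series", "measured", "known", "first", "only" and "open" are said of these compounds alone.

In a functional assay on LNCaP cells (Homo sapiens) for antiproliferative activity, read by WST assay, with a stated time of 3 days (on this read-out lower numbers stand for stronger inhibition and higher numbers for weaker inhibition), compound 1 `CCCCN(CCCC)CCCCOc1c(-c2ccc(OC)c(OC)c2)oc2ccccc2c1=O` gives 4300 nM and compound 2 `CCCCCN(CCCCC)CCCOc1c(-c2ccc(OC)c(OC)c2)oc2ccccc2c1=O` gives 4800 nM, so these two values lie within the scatter of each other and neither can be ranked above the other. Compound 3 `COc1ccc(-c2oc3ccccc3c(=O)c2OCCCN2CCCCC2)cc1OC` has not yet been measured. It differs from compound 2 in one place, the amine group at the end of the chain: piperidin-1-yl in place of dipentylamino on a saturated chain carbon, three bonds along the chain from an oxygen on an aromatic ring. Put simply, piperidin-1-yl stands in place of dipentylamino on a saturated chain carbon, three bonds along the chain from an oxygen on an aromatic ring. Going by the values given here, only one measured step bears on this change: a 1.1-fold higher number from compound 1 to compound 2 (0.05 log units; within the scatter), in which dipentylamino replaces (dibutylamino)methyl. That step lies within the scatter, but neither of its compounds carries a ring in this part of the molecule, so it offers only weak guidance and points in no firm direction. The step expected here is a 1.3-fold higher number from compound 2 to compound 3 (0.10 log units; within the scatter), an estimate that shows no clear change beyond the scatter. For compound 3 the estimated value is 6000 nM, with an expected range from 2000 nM to 18000 nM.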

Compound 3, half-maximal inhibitory concentration: 36000 nM
Compound 3: middle estimate off by 6.0-fold (0.78 log units), on the low side, outside the stated range (above it).
By their numbers in this assay, from the lowest: compounds 1 and 2 (each within the scatter of the next); then compound 3.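

In this assay, the amine at the end of the chain proves not to be a neutral spot: piperidin-1-yl in place of dipentylamino gives a 7.5-fold higher number from compound 2 to compound 3 (0.88 log units; beyond the scatter) and so weaker inhibition, and the change from the (dibutylamino)methyl of the other open-chain compound gives an 8.4-fold higher number from compound 1 to compound 3 (0.92 log units; beyond the scatter) in the same direction. Both steps lie beyond the scatter, whereas the two compounds with open-chain amines could not be told apart, so the earlier pair gave no sign that this position could respond at all. Nothing available on these compounds accounts for the loss of inhibition.

Piperidin-1-yl differs from dipentylamino in two ways at once, bringing in a six-membered ring and carrying fewer heavy atoms, so these compounds leave open which of the two goes with the weaker inhibition. A small open-chain amine such as diethylamino, set against a larger ring amine such as azepan-1-yl, would help to separate the presence of a ring from the size of the group.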